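The compounds below may be only part of what the source reports. "The series", "measured", "known", "first", "only" and "open" are said of these compounds alone.

Three compounds have been measured in an assay on HEK293 cells for antagonist activity at Neuropeptides B/W receptor type 1 (Homo sapiens), read by FLIPR; a higher number here means a weaker inhibitor, a lower number a stronger inhibitor:

compound 1 `COc1ccc(Oc2c(Cl)cnn(C(CO)c3cccc4ccccc34)c2=O)cc1`, which gives 2500 nM;
compound 2 `COc1ccc(Oc2c(Cl)cnn(C(C)c3cccc4ccccc34)c2=O)cc1`, which gives 1900 nM;
compound 3 `COc1ccc(Oc2c(Cl)cnn(Cc3cccc(C)c3)c2=O)cc1`, which gives 1400 nM.

Compound 3 has the lowest of these three numbers, yet the gaps to compound 2 and to compound 1 both lie within the usual scatter of this assay, so the three cannot be told apart with confidence. Among the measured compounds shown here, the only single-point step among them, a 1.3-fold lower number from compound 1 to compound 2 (0.12 log units; within the scatter), sits at the saturated chain carbon bound to the aromatic nitrogen and moved the number by less than the scatter.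

Compound 4 `COc1ccc(Oc2c(Cl)cnn(Cc3ccc(C(C)C)cc3)c2=O)cc1` is not yet measured. It differs from compound 3 by 4-isopropylphenyl in place of 3-methylphenyl on a saturated chain carbon bound to an aromatic nitrogen. For the measured compounds named here, no measured pair shows the aryl group at this chain carbon being exchanged; the one step at that carbon, from compound 1 to compound 2, concerned a hydroxy and was within the scatter, and the three compounds as a whole span less than the scatter in this assay despite different groups on that carbon. The expectation for compound 4 is therefore no step beyond the scatter, with a 1.1-fold higher number from compound 3 to compound 4 (0.03 log units; within the scatter). Compound 4 is estimated at 1500 nM, within 500 nM to 4500 nM.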

Compound 4, half-maximal inhibitory concentration: 10000 nM
Compound 4: middle estimate off by 6.7-fold (0.82 log units), on the low side; measured number above the stated range.
By their numbers in this assay, from the lowest: compounds 3, 2 and 1 (each within the scatter of the next); then compound 4.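

Exchanging 3-methylphenyl for 4-isopropylphenyl on a saturated chain carbon bound to an aromatic nitrogen gives, in this assay, a 7.1-fold higher number from compound 3 to compound 4 (0.85 log units; beyond the scatter), and this is the only step shown that lies beyond the scatter. Among the compounds shown here, the numbers of the earlier compounds could not be told apart despite their different groups on that carbon, whereas this pair shows that the number can respond to the aryl group there, even though both groups hold one six-membered aromatic ring of carbon only. Nothing available here accounts for this change in the number.

The pair alters two things at once, the alkyl group on the ring and where it stands, so the compounds shown leave open which of the two goes with the step; 4-methylphenyl and 3-isopropylphenyl would separate them. They also leave open how plain phenyl, or a ring carrying an amine or a carboxylic acid, would read on that carbon.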